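The compounds below may be only part of what the source reports. "The series", "measured", "known", "first", "only" and "open" are said of these compounds alone.

In an ADME assay on the whole organism (Rattus norvegicus) for pharmacokinetics, at a dose of 10 mg/kg by the oral route (on this read-out higher numbers stand for higher oral bioavailability and lower numbers for lower oral bioavailability), compound 1 `NC(=O)c1cc(Cl)c2c(Cl)c(C#CC3CCOCC3)n([C@H]3CCCNC3)c2n1` gives 67%, and compound 2 `COCCC#Cc1c(Cl)c2c(Cl)cc(C(N)=O)nc2n1[C@H]1CCCNC1` gives 46%.

Compound 2 therefore holds the lower of the two measured numbers. For the measured compounds named here, the only measured step, a number 21 percentage points lower from compound 1 to compound 2 (beyond the scatter), replaced a ring containing an oxygen with an open chain, and the number fell. Compound 3 `NC(=O)c1cc(Cl)c2c(Cl)c(C#CC3CCCO3)n([C@H]3CCCNC3)c2n1` differs from compound 2 by oxolan-2-yl in place of 2-methoxyethyl on a triple-bonded carbon, which brings back a ring containing an oxygen, though a smaller one. Going by the values given here, on that single precedent an upward step is expected, a number 14 percentage points higher from compound 2 to compound 3 (beyond the scatter), roughly undoing the earlier loss but with wide uncertainty since only one step informs it. Compound 3 is estimated at 60%, within 40% to 78%.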

Compound 3, oral bioavailability: 30%
The estimate for compound 3 lay 30 percentage points above the measured number; the measured number lies below the stated range.
By their numbers in this assay, from the lowest: compound 3; then compound 2; then compound 1.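

In this assay, a ring containing an oxygen on the triple-bonded carbon does not by itself keep the number high: oxolan-2-yl in place of 2-methoxyethyl gives a number 16 percentage points lower from compound 2 to compound 3 (beyond the scatter), and oxolan-2-yl in place of oxan-4-yl gives a number 37 percentage points lower from compound 1 to compound 3 (beyond the scatter). The open chain of compound 2 thus ranks above one ring and under the other, so ring against chain does not order these three compounds. Nothing measured here explains these steps.

Still open, on these data alone, is how a ring carrying an amine instead of the oxygen would compare at this position. As far as these compounds go, a longer chain ending in methoxy is equally open.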